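The compounds below may be only part of what the source reports. "The series", "measured", "known", "first", "only" and "open" are said of these compounds alone.

Measured so far in a functional assay on PC-3 cells (Homo sapiens) for cytotoxicity, read by MTT assay, with a stated time of 48 h; on this read-out lower numbers stand for stronger inhibition and higher numbers for weaker inhibition:
- compound 1, `CC(=O)Oc1ccccc1C1CC(C)=NN1C(=O)CN1CCCCC1`: 4070 nM
- compound 2, `CC(=O)Oc1ccccc1C1CC(C)=NN1C(=O)CN1CCC(C(C)=O)CC1`: 6800 nM

Going by the values given here, compound 2 and compound 1 lie within the scatter of each other: the only step in this assay, a 1.7-fold higher number from compound 1 to compound 2 (0.22 log units; within the scatter), does not separate the two, so no ranking of compound 2 against compound 1 is supported and the series so far spans a single narrow band of cytotoxicity.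

Compound 3, `CC(=O)Oc1ccccc1C1CC(C)=NN1C(=O)CCl`, is the next member. The change from compound 2 is chloro in place of 4-acetylpiperidin-1-yl on a saturated chain carbon bound to a carbonyl carbon. Among the compounds with values here, the one measured step concerned only the acetyl on the piperidine ring and left the ring itself in place; nothing measured removes the whole amine from the chain carbon or puts a halogen there. That step being within the scatter, it gives no direction for the present change, which is larger in kind than anything yet tested. The expectation is therefore anchored on compound 2 with a broad allowance: a step of a 1.4-fold lower number from compound 2 to compound 3 (0.13 log units; within the scatter), judged as none beyond the scatter, with the width of the range carrying the uncertainty. Compound 3 is thus estimated at 5000 nM in this assay, with a range from 1200 nM to 20000 nM.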

Compound 3, half-maximal inhibitory concentration: 3580 nM
Compound 3: middle estimate off by 1.4-fold (0.15 log units), on the high side; the measured number falls inside the stated range.
By their numbers in this assay, from the lowest: compounds 3, 1 and 2 (each within the scatter of the next).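

In this assay the whole amine on the saturated chain carbon bound to a carbonyl carbon gives way to chloro with no separation in the read-out: the exchange for 4-acetylpiperidin-1-yl gives a 1.9-fold lower number from compound 2 to compound 3 (0.28 log units; within the scatter) and the exchange for piperidin-1-yl gives a 1.1-fold lower number from compound 1 to compound 3 (0.06 log units; within the scatter) as its counterpart. The earlier step touched only the acetyl and kept the piperidine ring, whereas these two steps remove the ring and its nitrogen altogether, so among compound 1, compound 2 and compound 3 neither that ring nor an amine at this place is shown to be required for this level of cytotoxicity. No measurement is available to explain this flat result and the three compounds remain a single band.

Still open, on these data alone, is whether any other group on this chain carbon, such as a primary amine, a carboxylic acid or a longer alkyl chain, would give a number beyond the scatter from these three. Also open, as far as these compounds go, is whether the acetate ester on the shared core matters, for instance whether a free hydroxyl in its place would leave the number within that band.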